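Chloro for Bromo on the Cyanophenyl Ether

The source may hold more compounds than are shown below. What is called first, only, known or untested is meant among the compounds shown, and "the series" means these compounds.

Compound 1 `CC#CC(CC(=O)O)c1ccc(Oc2ncc(Br)cn2)cc1` and compound 2 `CC#CC(CC(=O)O)c1ccc(Oc2ccc(C#N)cc2Br)cc1` share a core that carries a carboxylic acid. In an assay on CHO cells for inhibition of Free fatty acid receptor 1 (Homo sapiens) (a higher number here means a weaker inhibitor, a lower number a stronger inhibitor), compound 1 gives 433 nM and compound 2 gives 36 nM, the lower of the two numbers, with compound 1 standing beyond the scatter above it. Compound 3 `CC#CC(CC(=O)O)c1ccc(Oc2ccc(C#N)cc2Cl)cc1` differs from compound 2 by chloro in place of bromo on an aromatic carbon. Among the measured compounds shown here, no measured step of this kind exists here, so compound 3 is expected to move little in this assay, if at all beyond the scatter. The expected step of a 1.4-fold higher number from compound 2 to compound 3 (0.14 log units; within the scatter) is slight. Compound 3 is estimated at 50 nM, within 20 nM to 130 nM.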

Compound 3, half-maximal inhibitory concentration: 23 nM
Estimate against measurement, compound 3: 2.2-fold (0.34 log units) above; the measured number falls inside the stated range.
By their numbers in this assay, from the lowest: compounds 3 and 2 (each within the scatter of the next); then compound 1.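

In this assay, chloro in place of bromo on this aromatic carbon, ortho to a large group and meta to a cyano group, gives a 1.6-fold lower number from compound 2 to compound 3 (0.19 log units; within the scatter). Among the compounds shown here, this position therefore takes either group with no difference beyond the scatter, which the earlier compounds could not show, as they offered no step at this place. Nothing measured here accounts for this result.

The compounds shown leave open how a fluoro or a methyl group on this same carbon would read. They also leave open whether an amine in place of the cyano group would keep the number this low.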